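This account rests on a few compounds, and the source may have more. Where it says the series, first, only, none or still open, it means among the compounds named here.

Series notes. Compound 1 `NC(=O)C[C@H](NC(=O)CN(c1nc(Cl)nc2[nH]cnc12)C1CC1)C(=O)O` gives 20.1% in a functional assay on the whole organism (Tail, strain ICR) with Mus musculus as the target, in the tail flick test, with a stated time of 90 min, at a dose of 25 umol/kg by the oral route; a lower number here means a weaker effect, a higher number a stronger effect of the compound at the dose given. Compound 2 `O=C(O)CNC(=O)CN(c1nc(Cl)nc2[nH]cnc12)C1CC1` gives 32.3% in this assay, and compound 3 `NC(=O)CC[C@H](NC(=O)CN(c1nc(Cl)nc2[nH]cnc12)C1CC1)C(=O)O` gives 41.1% in this assay. Among these, a number 12.2 percentage points higher from compound 1 to compound 2 (beyond the scatter), a number 21 percentage points higher from compound 1 to compound 3 (beyond the scatter) and a number 8.8 percentage points higher from compound 2 to compound 3 (within the scatter).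

Compound 4 `C[C@H](NC(=O)CN(c1nc(Cl)nc2[nH]cnc12)C1CC1)C(=O)O` has not yet been measured in this assay. It differs from compound 3 by hydrogen in place of carbamoylmethyl on a saturated chain carbon, two bonds along the chain from an amide-type nitrogen and a carbonyl carbon. The same change has already been made once, from compound 1 to compound 2, where it reads hydrogen in place of carbamoylmethyl on a saturated chain carbon bound to an amide-type nitrogen and a carbonyl carbon and produced a number 12.2 percentage points higher from compound 1 to compound 2 (beyond the scatter) in this assay. The two cores differ by carbamoylmethyl in place of carbamoyl on a saturated chain carbon, two bonds along the chain from an amide-type nitrogen and a carbonyl carbon. The places are not the same: in the earlier pair the group left a saturated chain carbon bound to an amide-type nitrogen and a carbonyl carbon, whereas here it leaves a saturated chain carbon two bonds along the chain from an amide-type nitrogen and a carbonyl carbon, so this is the same kind of change rather than the same change. For compound 4 the step is expected to be a number 1.1 percentage points lower from compound 3 to compound 4 (within the scatter) in this assay, smaller than the earlier one, because compound 2 already gives 32.3% while compound 3 gives 41.1%, two numbers within the scatter of each other. Compound 4 is therefore estimated at 40%, with 25% to 58% as the likely range.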

Compound 4, a percentage reported as activity, at one dose (the size of the read-out at that dose, not a potency): 43.5%
Beside the measured number, compound 4's estimate is 3.5 percentage points below it; measured number inside the range.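

The measured step is a number 2.4 percentage points higher from compound 3 to compound 4 (within the scatter) in this assay. Set side by side in this assay, the two readings of this change cannot be told apart: the same change on two cores in this assay, a number 12.2 percentage points higher (beyond the scatter) from compound 1 to compound 2 and a number 2.4 percentage points higher (within the scatter) from compound 3 to compound 4, 9.8 percentage points apart, within the scatter of two such steps. The change therefore carries from the core of compound 1 to the core of compound 3 without a measurable difference in size, but two pairs at a single dose give no potency and no rule for other cores. The series also shows a number 11.2 percentage points higher from compound 2 to compound 4 (beyond the scatter) for methyl in place of hydrogen, and a number 23.4 percentage points higher from compound 1 to compound 4 (beyond the scatter) for hydrogen in place of carbamoyl.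

The compounds shown leave open how a longer alkyl chain on the saturated chain carbon would read against the methyl of compound 4. They also leave open whether a carboxylic acid or an amine in place of carbamoyl would read with compound 1 or with compound 3.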